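The source may hold more compounds than are shown below. What is called first, only, known or untested is meant among the compounds shown, and "the series" means these compounds.

Of the compounds shown here, two built on a shared core have been tested in a functional assay on A-375 cells (Homo sapiens) for antiproliferative activity, read by MTT assay, with a stated time of 24 h, tested at 11.11 ug/mL; on this read-out higher numbers stand for a stronger effect at the one concentration tested and lower numbers for a weaker effect. Compound 1 `Cc1c(C(=O)Nc2c(F)cc(-c3cccc(F)c3)cc2F)nc2ccc(C(F)(F)F)cc2c1O` gives 46.3% in this assay, and compound 2 `Cc1c(C(=O)Nc2c(F)cc(-c3cccc(F)c3)cc2F)nc2ccc(F)cc2c1C(=O)O` gives 36.3% in this assay. Going by the values given here, compound 2 stands at the lower of these two numbers, yet its only neighbour, compound 1, lies within the usual scatter of it, so the two cannot be ranked against each other.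

Compound 3 `Cc1c(C(=O)Nc2c(F)cc(-c3cccc(F)c3)cc2F)nc2ccc(C(F)(F)F)cc2c1C(=O)O` differs from compound 2 by trifluoromethyl in place of fluoro on an aromatic carbon. Among the compounds with values here, no measured pair is separated by this change alone, so its effect has not been observed directly. The step of a number 5.7 percentage points higher from compound 2 to compound 3 (within the scatter) is expected to be small and not beyond the scatter, leaning if anything upward, because compound 1 gives 46.3% while also carrying trifluoromethyl, though it differs in a second place as well. Compound 3 is therefore estimated to give about 42% in this assay, with a likely range from 25% to 60%.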

Compound 3, a percentage reported as inhibition, at one concentration (the size of the read-out at that concentration, not a potency): 45.4%
Compound 3: the middle estimate sits 3.4 percentage points below what was measured, within the range that was stated.
By their numbers in this assay, from the lowest: compounds 2, 3 and 1 (each within the scatter of the next).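

Trifluoromethyl in place of fluoro on this aromatic carbon now has a direct measurement: in this assay the change gives a number 9.1 percentage points higher from compound 2 to compound 3 (within the scatter) and stays within the scatter, so this position shows no clear response to the swap at the one concentration tested. Compound 3 also gives the first single-place view of carboxy in place of hydroxy on an aromatic carbon, with a number 0.9 percentage points lower from compound 1 to compound 3 (within the scatter) and again no separation beyond the scatter. Nothing shown here explains why either step is so small.

Going by these compounds, whether a different group on the same aromatic carbon, such as an amine, a nitrile or a methoxy group, would move the read-out beyond the scatter remains open. Also open, on these data alone, is whether fluoro and hydroxy together on the shared core would give a similar number.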